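Hydroxy to methoxy on the side chain

This account rests on a few compounds, and the source may have more. Where it says the series, first, only, none or still open, it means among the compounds named here.

Three measured compounds share one core and differ only in the group on an oxygen on an aromatic ring. In a physicochemical assay for solubility, in phosphate buffer, measured as kinetic solubility, with a stated time of 24 h, at pH 6.5 (on this read-out higher numbers stand for higher solubility and lower numbers for lower solubility), compound 1 `CC(C)Oc1cc(Oc2cnc(C(=O)N(C)C)nc2)cc(-c2nccc(=O)[nH]2)c1` gives 332000 nM, compound 2 `CCC(CC)Oc1cc(Oc2cnc(C(=O)N(C)C)nc2)cc(-c2nccc(=O)[nH]2)c1` gives 469000 nM and compound 3 `C[C@@H](CO)Oc1cc(Oc2cnc(C(=O)N(C)C)nc2)cc(-c2nccc(=O)[nH]2)c1` gives 339000 nM. Compound 3 therefore stands within the scatter of both of the others.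

Compound 4 `COC[C@H](C)Oc1cc(Oc2cnc(C(=O)N(C)C)nc2)cc(-c2nccc(=O)[nH]2)c1` alters compound 3 in one place: methyl in place of hydrogen on an oxygen on a saturated carbon. Hydroxy becomes methoxy, which turns 1-(hydroxymethyl)ethyl into 1-(methoxymethyl)ethyl.

Going by the values given here, no measured step makes this exact change, but three steps altered the same group. Pentan-3-yl in place of isopropyl gave a 1.4-fold higher number from compound 1 to compound 2 (0.15 log units; within the scatter). Adding the hydroxy gave a 1.0-fold higher number from compound 1 to compound 3 (0.01 log units; within the scatter), and 1-(hydroxymethyl)ethyl in place of pentan-3-yl gave a 1.4-fold lower number from compound 2 to compound 3 (0.14 log units; within the scatter). None of the three compounds goes against this flat picture, so no step beyond the scatter is expected in this assay, only an estimated 1.0-fold higher number from compound 3 to compound 4 (0.01 log units; within the scatter). For compound 4 the expected value is 350000 nM, with an estimated range from 200000 nM to 600000 nM.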

Compound 4, solubility: 342000 nM
Compound 4: the middle estimate sits 1.0-fold (0.01 log units) above what was measured; low and high end bracket the measured number.
By their numbers in this assay, from the lowest: compounds 1, 3, 4 and 2 (each within the scatter of the next).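

In this assay methyl can take the place of the hydrogen on the side-chain oxygen with a 1.0-fold higher number from compound 3 to compound 4 (0.00 log units; within the scatter) so among these compounds a free hydroxy is not needed to keep the number where it stands. Compared with the other two side chains, the 1-(methoxymethyl)ethyl group gives a 1.0-fold higher number from compound 1 to compound 4 (0.01 log units; within the scatter) and a 1.4-fold lower number from compound 2 to compound 4 (0.14 log units; within the scatter) so it lies within the scatter of both. Going by these compounds alone, all four groups on this oxygen now give numbers within the scatter of one another, and no compound goes against that flat picture.

As far as these compounds go, whether an amine, a carboxylic acid or a longer chain ending in methoxy at this position would move the number beyond the scatter remains open. Nothing shown here gives a reason for the flat picture.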